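Trimming the Amine: From Compound 2 to Compound 4

The compounds below may be only part of what the source reports. "The series", "measured", "known", "first", "only" and "open" are said of these compounds alone.

Three measured compounds share a two-ring core carrying an ether on one side and an amine on the other. Among the compounds with values here, compound 1 `Nc1ccc2cccc(OCCC3CCCCC3)c2n1` is the only one that gives a number: in an assay on cells with melanin-concentrating hormone receptor 1 (Homo sapiens) as the target, read by radioligand binding (a lower number here means a stronger inhibitor, a higher number a weaker inhibitor), compound 1 gives 808 nM. Compound 2 `CC(CC(C)(C)C)Oc1cccc2ccc(N3CCCC3)nc12` reaches only the limit of this assay and gives > 2000 nM. Compound 3 `CC(C)=CCOc1cccc2ccc(N)nc12` likewise stops at the limit, giving > 2000 nM. Compound 2 therefore stands at the limit of > 2000 nM in this assay, at which 2 of the 3 values shown sit, so that no number separates it from compound 3 and its true value is not known. Compound 4 `CNc1ccc2cccc(OC(C)CC(C)(C)C)c2n1` keeps the ether of compound 2 and alters the amine: methylamino in place of pyrrolidin-1-yl on an aromatic carbon. Within the data shown here, no measured pair isolates this change, so its size is open. Among the measured compounds shown here, compound 1, the sole numbered compound, carries an amine with no ring, whereas compound 2 carries the ring amine, which hints that the methylamino of compound 4 might bring the value back into the measurable range, though the ether differs between them too. Compound 4 is expected at 1500 nM, within 400 nM to 6000 nM. This expectation implies a step of an at least 1.3-fold lower number from compound 2 to compound 4 (0.12 log units; that floor lies within the scatter) from the limit, of uncertain size.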

Compound 4, half-maximal inhibitory concentration: 310 nM
Compound 4: the middle estimate sits 4.8-fold (0.68 log units) above what was measured; the measured number lies below the stated range.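

With the ether held fixed, methylamino in place of pyrrolidin-1-yl gives, in this assay, an at least 6.4-fold lower number from compound 2 to compound 4 (0.80 log units; beyond the scatter), which shows that the amine at this position, next to the ring nitrogen, can decide whether a compound reaches the measurable range. The true size of this step stays unknown because compound 2 holds only a limit: the limit of > 2000 nM in this assay, at which 2 of the 4 values shown sit.

The change removes a ring and brings in a hydrogen-bond donor at once, so this single pair cannot tell which of the two matters. A dimethylamino group in the same place, with the same ether, would separate the loss of the ring from the gain of the donor. From the compounds shown here alone, whether the same amine change holds with the ether of compound 1 or compound 3 also remains open.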